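A few compounds are considered here, and "the series" means these few. Any claim that something is new, unique, unknown or untested is made for them only; others in the source may bear on it.

Measured so far in a functional assay on MDA-MB-231 cells (Homo sapiens) for cytotoxicity, read by MTT assay, with a stated time of 72 h; on this read-out lower numbers stand for stronger inhibition and higher numbers for weaker inhibition:
- Compound 1 `O=C(CN1CCN(c2nnc(Cc3ccncc3)c3ccccc23)CC1)Nc1cccc(Br)c1`: 1.7 nM
- Compound 2 `Cc1cccc(Cl)c1NC(=O)CN1CCN(c2nnc(Cc3ccccc3)c3ccccc23)CC1`: 3920 nM

Compound 1 has the lower number of the two, and the gap to compound 2 lies well beyond the scatter. The two compounds differ in more than one place, however, so their values cannot be tied to any single structural change.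

Compound 3 `O=C(CN1CCN(c2nnc(Cc3ccncc3)c3ccccc23)CC1)Nc1c(F)cccc1F` keeps the rest of compound 1 and changes one group: 2,6-difluorophenyl in place of 3-bromophenyl on an amide-type nitrogen. It carries 2,6-difluorophenyl in place of 3-bromophenyl on an amide-type nitrogen. For the measured compounds named here, no measured pair shows what this swap does. The expectation rests on compound 1 at 1.7 nM, a number so low that a change of group is more likely to raise it than to lower it. The expected rise, beyond the scatter, is a 35-fold higher number from compound 1 to compound 3 (1.55 log units; beyond the scatter). For compound 3 the estimate is 60 nM, with an expected range of 4 nM to 1500 nM.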

Compound 3, half-maximal inhibitory concentration: 1900 nM
The estimate for compound 3 lay 32-fold (1.50 log units) below the measured number; the whole stated range lies below it.
By their numbers in this assay, from the lowest: compound 1; then compound 3; then compound 2.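

In this assay, the group on the amide-type nitrogen has a strong hold on the number: with the rest of the molecule unchanged, 2,6-difluorophenyl in place of 3-bromophenyl gives a 1100-fold higher number from compound 1 to compound 3 (3.05 log units; beyond the scatter) and removes nearly all of the low value of compound 1. For the compounds shown here, this is the first comparison here that differs in one place only, so part of that low value can now be tied to this group rather than to the shared core. Nothing measured here explains why this swap has such a large effect.

The swap changes the kind, number and placement of the halogens all at once, so the compounds shown cannot separate these changes; 3-chlorophenyl or 3-fluorophenyl would test the kind of halogen alone. Also open, from the compounds shown here alone, is how a non-aromatic group, such as cyclohexyl, would fare on this nitrogen.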